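This account rests on a few compounds, and the source may have more. Where it says the series, first, only, none or still open, it means among the compounds named here.

Compound 1 `COc1cc(/C=C/C(=O)c2ccc(OCCCSC(=S)N3CCN(C)CC3)cc2)cc(OC)c1OC` gives 2030 nM; compound 2 `CN1CCN(C(=S)SCCCOc2ccc(C(=O)/C=C/c3cc(F)cc(F)c3)cc2)CC1` gives 13200 nM; compound 3 `COc1cc(/C=C/C(=O)c2ccc(OCCSC(=S)N3CCCC3)cc2)cc(OC)c1OC` gives 12100 nM in a functional assay on SK-N-SH cells (Homo sapiens) for inhibition, read by MTT assay, with a stated time of 72 h; a higher number here means a weaker inhibitor, a lower number a stronger inhibitor.

Among these three numbers compound 3 stands second highest, next to compound 2 and well apart from compound 1. Compound 4 `COc1cc(/C=C/C(=O)c2ccc(OCCSC(=S)N3CCN(C)CC3)cc2)cc(OC)c1OC` differs from compound 3 by 4-methylpiperazin-1-yl in place of pyrrolidin-1-yl on a thiocarbonyl carbon. Among the measured compounds shown here, the one measured step that bears on this is a 6.0-fold higher number from compound 1 to compound 3 (0.78 log units; beyond the scatter), where the larger group of 11 heavy atoms with two nitrogens was replaced by the smaller group of 8; that step ran in the opposite direction to the present one, though it also covered a change in the chain that compound 4 does not share. Compound 4 is therefore expected to give a lower number in this assay, a step of about a 3.0-fold lower number from compound 3 to compound 4 (0.48 log units; beyond the scatter). Compound 4 is estimated at 4000 nM, within 1500 nM to 12000 nM.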

Compound 4, half-maximal inhibitory concentration: 2460 nM
Beside the measured number, compound 4's estimate is 1.6-fold (0.21 log units) above it, within the range that was stated.
By their numbers in this assay, from the lowest: compounds 1 and 4 (each within the scatter of the next); then compounds 3 and 2 (each within the scatter of the next).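

In this assay, the step of a 4.9-fold lower number from compound 3 to compound 4 (0.69 log units; beyond the scatter) isolates 4-methylpiperazin-1-yl in place of pyrrolidin-1-yl on a thiocarbonyl carbon, free of the chain difference that the earlier step from compound 1 to compound 3 also carried. With the 4-methylpiperazin-1-yl group kept, the change in the chain gives a 1.2-fold higher number from compound 1 to compound 4 (0.08 log units; within the scatter) and so does not separate the two compounds. Nothing available accounts for the difference between the two rings.

On these data alone, whether the lower number follows the second ring nitrogen, the methyl or the ring size stays open. The compounds shown include no piperidin-1-yl, morpholin-4-yl or unsubstituted piperazin-1-yl group on the thiocarbonyl carbon to tell these apart.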